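Series notes: methyl for trifluoromethyl, second occurrence

A few compounds are considered here, and "the series" means these few. Any claim that something is new, unique, unknown or untested is made for them only; others in the source may bear on it.

Measured compounds:
- compound 1, `NC(=O)c1c(NC(=O)c2ccc(C(F)(F)F)cc2)sc2c1CCN(Cc1ccc(Cl)cc1Cl)C2`; in a functional assay on MKN-74 cells (Homo sapiens) for antiproliferative activity, with a stated time of 24 h (a lower number here means a stronger inhibitor, a higher number a weaker inhibitor), compound 1 gives 10900 nM
- compound 2, `Cc1ccc(C(=O)Nc2sc3c(c2C(N)=O)CCN(Cc2ccc(Cl)cc2Cl)C3)cc1`; in this assay compound 2 gives 25500 nM
- compound 3, `NC(=O)c1c(NC(=O)c2ccc(C(F)(F)F)cc2)sc2c1CCN(C(=S)Nc1ccccc1Cl)C2`; in this assay compound 3 gives 16400 nM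

The change from compound 1 to compound 2 is methyl in place of trifluoromethyl on an aromatic carbon, and it made a 2.3-fold higher number from compound 1 to compound 2 (0.37 log units; beyond the scatter). The same change is now applied on a second core: compound 4, `Cc1ccc(C(=O)Nc2sc3c(c2C(N)=O)CCN(C(=S)Nc2ccccc2Cl)C3)cc1`, differs from compound 3 by methyl in place of trifluoromethyl on an aromatic carbon. The two cores differ by a group of 10 heavy atoms (7 carbon, 1 nitrogen, 1 sulfur, 1 chlorine; one six-membered aromatic ring of carbon only) in place of a group of 9 heavy atoms (7 carbon, 2 chlorine; one six-membered aromatic ring of carbon only), on an amine nitrogen in a ring, a change that gave a 1.5-fold higher number from compound 1 to compound 3 (0.18 log units; within the scatter). Compound 2 and compound 3 lie within the scatter of each other, so no order is read between them. Among the compounds shown the methyl for trifluoromethyl change occurs twice in all, and the place is the same word for word on both cores, so it counts as the same change. Within the data shown here, only one measured instance of it exists, and the core change itself stayed within the scatter, so the single step is carried over as it stands. For compound 4 a step of a 2.3-fold higher number from compound 3 to compound 4 (0.36 log units; beyond the scatter) in this assay is expected, beside the earlier 2.3-fold higher number from compound 1 to compound 2 (0.37 log units; beyond the scatter). Compound 4 is thus estimated at 38000 nM in this assay, with a likely range from 20000 nM to 75000 nM.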

Compound 4, half-maximal inhibitory concentration: 11300 nM
For compound 4 the middle estimate is 3.4-fold (0.53 log units) above the measured one, outside the stated range (below it).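

In this assay, methyl in place of trifluoromethyl gave a 1.5-fold lower number from compound 3 to compound 4 (0.16 log units; within the scatter), so on this core the step stays within the scatter, and the larger step on the core of compound 1 did not carry over: the same change on two cores in this assay, a 2.3-fold higher number (0.37 log units; beyond the scatter) from compound 1 to compound 2 and a 1.5-fold lower number (0.16 log units; within the scatter) from compound 3 to compound 4, 3.4-fold (0.53 log units) apart, beyond the scatter of two such steps. Read the other way, the change of group on the amine nitrogen in the ring gave a 2.3-fold lower number from compound 2 to compound 4 (0.35 log units; beyond the scatter) with methyl in place, so that step also depends on the group at the other site: the same change on two cores in this assay, a 1.5-fold higher number (0.18 log units; within the scatter) from compound 1 to compound 3 and a 2.3-fold lower number (0.35 log units; beyond the scatter) from compound 2 to compound 4, 3.4-fold (0.53 log units) apart, beyond the scatter of two such steps. The two changes therefore do not add independently across these four compounds, but with one pair per core the data do not show which core departs from the other, nor how the step would read on a further core.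

Still open, as far as these compounds go, is how a nitrile, a methoxy or a carboxylic acid on the same aromatic carbon would read on the two cores, and whether a longer chain on the ring amine nitrogen would show the same dependence. All of these readings also rest on a single cell assay at one stated time.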